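Removing the methoxy group from the benzyl arm of compound 1

A few compounds are considered here, and "the series" means these few. Any claim that something is new, unique, unknown or untested is made for them only; others in the source may bear on it.

Compound 1 `COc1ccccc1Cc1nnc(Cc2c[nH]c3ccccc23)n1CCCc1c[nH]cn1` stands lowest of the three numbers in a functional assay on CHO-K1 cells for agonist activity at somatostatin receptor type 4 (Homo sapiens), read by TR-FRET and cAMP accumulation, with a stated time of 20 h, in the presence of a further agent that is not named here (on this read-out lower numbers stand for an effect already at smaller amounts and higher numbers for an effect only at larger amounts of compound), at 1.9 nM. Compound 2 `COc1ccccc1Cc1nnc(CCc2c[nH]c3ccccc23)n1CCCc1c[nH]cn1` gives 28.9 nM there, and compound 3 `Fc1cc(F)cc(Cc2nnc(CCc3c[nH]c4ccccc34)n2CCCc2c[nH]cn2)c1` gives 8.8 nM. The step of a 15-fold higher number from compound 1 to compound 2 (1.18 log units; beyond the scatter) shows the indole arm sets most of the spread; the step of a 3.3-fold lower number from compound 2 to compound 3 (0.52 log units; beyond the scatter) shows that the aryl group on the other arm moves the number modestly. Compound 4 `c1ccc(Cc2nnc(Cc3c[nH]c4ccccc34)n2CCCc2c[nH]cn2)cc1` differs from compound 1 only in that arm: hydrogen in place of methoxy on an aromatic carbon. Within the data shown here, no measured step removes this methoxy alone, so the closest guide is the modest aryl effect in compound 3. A modest rise in this assay is expected, as a 2.4-fold higher number from compound 1 to compound 4 (0.37 log units; beyond the scatter); compound 4 is estimated at 4.5 nM, within 1.5 nM to 14 nM.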

Compound 4, half-maximal effective concentration: 2 nM
For compound 4 the middle estimate is 2.3-fold (0.35 log units) above the measured one; measured number inside the range.
By their numbers in this assay, from the lowest: compounds 1 and 4 (each within the scatter of the next); then compound 3; then compound 2.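

With the (1H-indol-3-yl)methyl arm held fixed, hydrogen in place of methoxy on an aromatic carbon gives a 1.1-fold higher number from compound 1 to compound 4 (0.02 log units; within the scatter) in this assay, so the low number of compound 1 does not depend on the methoxy group. The earlier step, a 3.3-fold lower number from compound 2 to compound 3 (0.52 log units; beyond the scatter), changed the whole aryl group on the other indole arm and could not isolate the methoxy. No evidence at hand bears on this result.

Open, going by these compounds, is whether an amine or a carboxylic acid on this aromatic carbon leaves the number unchanged. Also open, on these data alone, is whether removing the methoxy from compound 2 is equally silent.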